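Compound 4: will a swapped group leave the limit?

The source may report more compounds than this note shows. Statements on the series, on what has been measured and on what is new or still open speak of the compounds shown alone.

- Compound 1 `O=C(NC[C@@H]1[C@H]2CN(C(=O)OCc3cc(Cl)cc(Cl)c3)C[C@@H]12)c1ccc2[nH]c(=O)oc2c1`: < 1 ug/mL, a limit
- Compound 2 `O=C(NC[C@@H]1[C@H]2CN(C(=O)CCc3cc(Cl)cc(Cl)c3)C[C@@H]12)c1ccc2[nH]c(=O)oc2c1`: < 1 ug/mL, a limit
- Compound 3 `O=C(NC[C@@H]1[C@H]2CN(C(=O)C3CC3c3cc(Cl)cc(Cl)c3)C[C@@H]12)c1ccc2[nH]c(=O)oc2c1`: < 1 ug/mL, a limit

All three compounds were tested in a physicochemical assay for solubility, with a stated time of 24 h, at pH 2.2; a lower number here means a less soluble compound, a higher number a more soluble compound. Compound 3 gives a limit and not a number, and it sits with the other two at the limit of < 1 ug/mL in this assay, at which 3 of the 3 values shown sit. Compound 4 `CC(OC(=O)N1C[C@@H]2[C@@H](CNC(=O)c3ccc4[nH]c(=O)oc4c3)[C@@H]2C1)c1cc(Cl)cc(Cl)c1` has not been measured, and the change to it is a group of 11 heavy atoms (8 carbon, 1 oxygen, 2 chlorine; one six-membered aromatic ring of carbon only) in place of a group of 11 heavy atoms (9 carbon, 2 chlorine; one three-membered non-aromatic ring of carbon only, one six-membered aromatic ring of carbon only), on a carbonyl carbon. Three measured swaps on this carbonyl carbon bear on it: a step that the two limits leave unreadable from compound 1 to compound 2, a step that the two limits leave unreadable from compound 1 to compound 3 and a step that the two limits leave unreadable from compound 2 to compound 3. None of them has a readable size, so no step beyond the usual scatter is expected in this assay. The expected result is a step that the limit leaves unreadable from compound 3 to compound 4. For compound 4 the estimated value is 0.7 ug/mL, with an expected range from 0.3 ug/mL to 1.5 ug/mL.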

Compound 4, solubility: < 1 ug/mL
Compound 4: only a limit was reported; the forecaster's own chance of this, stated with the estimate: 80%; the middle value lies beyond the limit too.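

Compound 4 gives only a limit, < 1 ug/mL, so no step among compound 1, compound 2, compound 3 and compound 4 can be read: the limit of < 1 ug/mL in this assay, at which 4 of the 4 values shown sit.

From the compounds shown here alone, the actual solubility of these four compounds, and whether they differ at all, stays open.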